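Second chlorine on the purine core of compound 1

The source may report more compounds than this note shows. Statements on the series, on what has been measured and on what is new or still open speak of the compounds shown alone.

Among the compounds with values here, in a functional assay on SF-268 cells (Homo sapiens) for cytotoxicity, read by sulforhodamine B assay, with a stated time of 48 h (a higher number here means a weaker inhibitor of growth, a lower number a stronger inhibitor of growth), compound 1 `ClCc1cccc(Cn2cnc3ncnc(Cl)c32)c1` gives 3460 nM, the lowest of the two numbers known here. Its isomer compound 2 `ClCc1cccc(Cn2cnc3c(Cl)ncnc32)c1` gives 15500 nM in this assay, a gap beyond the scatter. Compound 3 `ClCc1cccc(Cn2cnc3nc(Cl)nc(Cl)c32)c1` is not yet measured; it differs from compound 1 by chloro in place of hydrogen on an aromatic carbon, a chloro in place of hydrogen on an aromatic carbon of the shared core. Within the data shown here, no comparable step has been measured, so only a small change in this assay is expected, within the scatter, as a 1.4-fold lower number from compound 1 to compound 3 (0.14 log units; within the scatter). Compound 3 is therefore estimated at 2500 nM, with a range from 800 nM to 8000 nM.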

Compound 3, concentration for total growth inhibition: 3800 nM
Beside the measured number, compound 3's estimate is 1.5-fold (0.18 log units) below it, and the stated range covers the measured number.
By their numbers in this assay, from the lowest: compounds 1 and 3 (each within the scatter of the next); then compound 2.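

In this assay, a chloro on the aromatic carbon between two ring nitrogen atoms gives a 1.1-fold higher number from compound 1 to compound 3 (0.04 log units; within the scatter), so compound 1 and compound 3 cannot be told apart. This position of the shared core therefore takes a chloro as well as a hydrogen in this read-out. Nothing measured here explains this result. On these data alone, whether an amine or a methoxy group on the same carbon would also match compound 1 stays open. So does whether this chloro would give the same result on the core of compound 2.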